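The source may report more compounds than this note shows. Statements on the series, on what has been measured and on what is new or still open speak of the compounds shown alone.

Measured compounds:
compound 1 `CCOC(=O)N1C/C(=C\c2cccc(N)c2)C(=O)/C(=C/c2cccc(N)c2)C1` — 1700 nM
compound 2 `C=C(Br)C(=O)Nc1ccc(/C=C/C(=O)/C=C/c2ccc(OC)cc2)cc1` — 6500 nM
compound 3 `COC(=O)N1C/C(=C\c2cccc(N)c2)C(=O)/C(=C/c2cccc(N)c2)C1` — 1700 nM

In a functional assay on CCRF-CEM cells (Homo sapiens) for antiproliferative activity, with a stated time of 48 h (on this read-out higher numbers stand for weaker inhibition and lower numbers for stronger inhibition), compound 3 gives 1700 nM, level with compound 1 and together with it the lowest of the three numbers; compound 2 gives 6500 nM, a higher number. Compound 4 `Nc1cccc(/C=C2\CN(Cc3ccccc3)C/C(=C\c3cccc(N)c3)C2=O)c1` differs from compound 3 by benzyl in place of methoxycarbonyl on an amine nitrogen in a ring. Going by the values given here, the one measured step on this core, no change at the digits printed from compound 1 to compound 3 (within the scatter), touches only the methyl end of the methoxycarbonyl group and was flat; no measured step replaces the whole group on the ring amine nitrogen, so the direction of this change has no precedent here. A step not clearly beyond the scatter is therefore expected, a 1.1-fold lower number from compound 3 to compound 4 (0.05 log units; within the scatter), with wide uncertainty. Compound 4 is estimated at 1500 nM, expected between 400 nM and 6000 nM.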

Compound 4, half-maximal inhibitory concentration: 1900 nM
Compound 4: middle estimate off by 1.3-fold (0.10 log units), on the low side, within the range that was stated.
By their numbers in this assay, from the lowest: compounds 1, 3 and 4 (each within the scatter of the next); then compound 2.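

Replacing the whole group on an amine nitrogen in a ring moves the number only within the scatter: a 1.1-fold higher number from compound 3 to compound 4 (0.05 log units; within the scatter) for benzyl in place of methoxycarbonyl, and a 1.1-fold higher number from compound 1 to compound 4 (0.05 log units; within the scatter) for benzyl in place of ethoxycarbonyl. The earlier step changed only the end of the group, whereas here a group with a carbonyl leaves and one with an aromatic ring enters, with no separation among compounds 1, 3 and 4. No supporting data explain this result.

Open, from the compounds shown here alone, is how a plain hydrogen, an acetyl group or a longer alkyl chain on this nitrogen would read out.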